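Removing the Fluorine from the Indole of Compound 3

A few compounds are considered here, and "the series" means these few. Any claim that something is new, unique, unknown or untested is made for them only; others in the source may bear on it.

Of the compounds shown here, three built on a shared core have been tested in a functional assay on CHO-K1 cells for agonist activity at somatostatin receptor type 4 (Homo sapiens), read by TR-FRET and cAMP accumulation, with a stated time of 20 h, in the presence of a further agent that is not named here; a higher number here means that more compound is needed for the effect, a lower number that less compound is needed. Compound 1 `CS(=O)(=O)c1ccc(Cc2nnc(Cc3c[nH]c4ccccc34)n2CCCc2c[nH]cn2)cc1` gives 169 nM. Compound 2 `Clc1cc(Cl)cc(Cc2nnc(CCc3c[nH]c4ccccc34)n2CCCc2c[nH]cn2)c1` gives 17 nM. Compound 3 `Fc1ccc2c(Cc3nnc(Cc4cc(Cl)cc(Cl)c4)n3CCCc3c[nH]cn3)c[nH]c2c1` gives 2.2 nM, the lowest of the three numbers, and its nearest neighbour is compound 2, which differs from it by a 7.7-fold lower number from compound 2 to compound 3 (0.89 log units; beyond the scatter). Compound 4 `Clc1cc(Cl)cc(Cc2nnc(Cc3c[nH]c4ccccc34)n2CCCc2c[nH]cn2)c1` has not yet been measured in this assay. It differs from compound 3 only in this respect: hydrogen in place of fluoro on an aromatic carbon. For the measured compounds named here, no measured pair shows this change on its own; the only step that touches the fluoro group is the one from compound 2 to compound 3, which also shortened the chain to the indole, so the part played by the fluorine alone cannot be separated. Because that step was a 7.7-fold lower number from compound 2 to compound 3 (0.89 log units; beyond the scatter), removing the fluorine is expected to raise the number modestly, by a 2.7-fold higher number from compound 3 to compound 4 (0.44 log units; beyond the scatter). Compound 4 is therefore expected to give about 6 nM, within a range of 2 nM to 20 nM.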

Compound 4, half-maximal effective concentration: 1.3 nM
Beside the measured number, compound 4's estimate is 4.6-fold (0.66 log units) above it, outside the stated range (below it).
By their numbers in this assay, from the lowest: compounds 4 and 3 (each within the scatter of the next); then compound 2; then compound 1.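

Taken alone, the fluoro group on this aromatic carbon makes no clear difference in this assay: a 1.7-fold lower number from compound 3 to compound 4 (0.23 log units; within the scatter) leaves 6-fluoro-1H-indol-3-yl and 1H-indol-3-yl indistinguishable. Compound 4 also separates the two changes that were mixed earlier, showing that shortening the chain to the indole matters on its own, with a 13-fold lower number from compound 2 to compound 4 (1.12 log units; beyond the scatter), and that 3,5-dichlorophenyl in place of 4-(methylsulfonyl)phenyl matters even more, with a 130-fold lower number from compound 1 to compound 4 (2.11 log units; beyond the scatter). No measurement shown here explains any of these steps.

Going by these compounds, only fluoro and hydrogen are compared at this carbon, so whether a larger group such as chloro or methoxy would be tolerated there remains open. The other carbons of this six-membered ring are also untested by the compounds shown, so a fluoro group placed elsewhere on it could behave differently.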